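Hydrazone aryl swap on a shared core: compound 4

This account rests on a few compounds, and the source may have more. Where it says the series, first, only, none or still open, it means among the compounds named here.

Measured compounds:
compound 1 `Cn1c(=O)c(=O)n(C2CCCC2)c2nc(N/N=C/c3ccc(F)c(Cl)c3)ncc21` gives 9410 nM
compound 2 `Cn1c(=O)c(=O)n(C2CCCC2)c2nc(N/N=C/c3ccco3)ncc21` gives > 100000 nM
compound 3 `Cc1cc(C)c(/C=N/Nc2ncc3c(n2)n(C2CCCC2)c(=O)c(=O)n3C)c(C)c1` gives 12000 nM

Compound 1 carries the 3-chloro-4-fluorophenyl group on a carbon with a double bond to nitrogen, and in a functional assay on A549 cells (Homo sapiens) for antiproliferative activity, read by MTT assay (a higher number here means a weaker inhibitor, a lower number a stronger inhibitor), compound 1 gives 9410 nM, the lowest of the two numbers shown. Compound 3 sits close, since a 1.3-fold higher number from compound 1 to compound 3 (0.11 log units; within the scatter). Compound 2 reaches only a limit of this assay, > 100000 nM, so it has no number. The step of an at least 10-fold higher number from compound 1 to compound 2 (1.02 log units; beyond the scatter) is large, and so is the reverse direction, an at least 8.3-fold lower number from compound 2 to compound 3 (0.92 log units; beyond the scatter).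

Compound 4 `Cn1c(=O)c(=O)n(C2CCCC2)c2nc(N/N=C/c3ccccc3F)ncc21` differs from compound 1 in one place: 2-fluorophenyl in place of 3-chloro-4-fluorophenyl on a carbon with a double bond to nitrogen. Two of the measured steps bear on it. The swap between two substituted phenyl groups, a 1.3-fold higher number from compound 1 to compound 3 (0.11 log units; within the scatter), stayed within the scatter, while only the change to furan-2-yl moved the number beyond it. Since compound 4 keeps a phenyl ring with a halogen, the step of a 1.6-fold higher number from compound 1 to compound 4 (0.20 log units; within the scatter) is expected to be small, most likely a slightly higher number, within or barely beyond the scatter. Compound 4 is therefore estimated at 15000 nM, with a range from 6000 nM to 50000 nM.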

Compound 4, half-maximal inhibitory concentration: 31200 nM
Compound 4: the middle estimate sits 2.1-fold (0.32 log units) below what was measured; low and high end bracket the measured number.
By their numbers in this assay, from the lowest: compounds 1 and 3 (each within the scatter of the next); then compound 4. At a limit, above all of these: compound 2.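

Among substituted phenyl groups on a carbon with a double bond to nitrogen, the choice of ring now registers in this assay: a 3.3-fold higher number from compound 1 to compound 4 (0.52 log units; beyond the scatter), whereas the earlier swap between two phenyl groups stayed within the scatter. Compound 4 also parts from the trimethylated ring, with a 2.6-fold higher number from compound 3 to compound 4 (0.41 log units; beyond the scatter), so 2-fluorophenyl gives a higher number than both 3-chloro-4-fluorophenyl and 2,4,6-trimethylphenyl, and a halogen-bearing phenyl ring alone does not hold the number at the level of compound 1. The 2-fluorophenyl ring still gives a lower number than furan-2-yl, with an at least 3.2-fold lower number from compound 2 to compound 4 (0.50 log units; beyond the scatter), but that step can only be read as a minimum, as compound 2 stands at a limit rather than a number: the limit of > 100000 nM in this assay, at which 1 of the 4 values shown sits.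

The compounds shown leave open how much of the gap between compound 1 and compound 4 belongs to the chlorine and how much to where the fluorine sits on the ring. They also leave open how a phenyl ring bearing an amine or a carboxylic acid, or a pyridine ring in place of the furan, would read in this assay.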